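The compounds below may be only part of what the source reports. "The series", "measured", "known", "first", "only" and "open" are said of these compounds alone.

Three compounds share a common core and were examined in a functional assay on the whole organism for inhibition, with Rattus norvegicus as the target; on this read-out lower numbers stand for an effect already at smaller amounts and higher numbers for an effect only at larger amounts of compound. Compound 1 `CN(C)C(=O)n1cc(C(=O)c2ccn3c2CSC3c2cccnc2)c2ccc(-c3ccccc3)cc21` gives 0.03 mg/kg in this assay. Compound 2 `CN(C)C(=O)n1cc(C(=O)c2ccn3c2CSC3c2cccnc2)c2ccc(Oc3ccc(F)cc3)cc21` gives 0.03 mg/kg, and no change at the digits printed from compound 1 to compound 2 (within the scatter). Compound 3 `NC(=O)n1cc(C(=O)c2ccn3c2CSC3c2cccnc2)c2ccc(-c3ccc(F)cc3)cc21` gives 0.01 mg/kg, the lowest of the three numbers, and both its neighbours stand at numbers beyond the scatter, so within this small set compound 3 is the most potent. Compound 3 differs from compound 1 in two places, at the carbamoyl group and at the phenyl group, so no single step can be read between them; the two values alone show that compound 3 is reached at the smaller dose.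

Compound 4 `NNC(=O)n1cc(C(=O)c2ccn3c2CSC3c2cccnc2)c2ccc(-c3ccc(F)cc3)cc21` carries the change (amino in place of hydrogen on an amide-type nitrogen), turning the carbamoyl into an aminocarbamoyl. For the measured compounds named here, no measured step touches this position: the one step that is known, from compound 1 to compound 2, concerns the aromatic carbon and shows no change beyond the scatter. That gives no guide for a change on the amide-type nitrogen, and the direction of the coming step is open. The estimate for compound 4 in this assay is therefore anchored on compound 3 and is 0.02 mg/kg, with a range from 0.007 mg/kg to 0.06 mg/kg, which means an expected step of a 2.0-fold higher number from compound 3 to compound 4 (0.30 log units; within the scatter).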

Compound 4, dose for half-maximal effect: 0.04 mg/kg
Estimate against measurement, compound 4: 2.0-fold (0.30 log units) below; measured number inside the range.
By their numbers in this assay, from the lowest: compound 3; then compounds 1, 2 and 4 (each within the scatter of the next).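

In this assay, the amide-type nitrogen proves to be a place where a single change moves the number: amino in place of hydrogen gives a 4.0-fold higher number from compound 3 to compound 4 (0.60 log units; beyond the scatter), a modest step. For the compounds shown here, the only earlier step, no change at the digits printed from compound 1 to compound 2 (within the scatter), concerned an aromatic carbon and said nothing about this nitrogen, so this is the first sign that the carbamoyl of compound 3 and the aminocarbamoyl of compound 4 do not stand level, with the change from carbamoyl to aminocarbamoyl going towards a larger dose. No measurement at hand bears on what lies behind this step.

Only amino is shown as a replacement for the amide hydrogen on the fluorophenyl-bearing compounds, so it remains open whether a methyl group, a hydroxyl group or a longer chain such as an aminoethyl group at this nitrogen would follow the same direction. The dimethylcarbamoyl compounds, compound 1 and compound 2, differ from compound 3 and compound 4 in more than one place, so these steps cannot be read, and what the dimethyl groups contribute on their own stays undetermined.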